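Triazolylmethyl aryl swap at the weak end of the series

The source may report more compounds than this note shows. Statements on the series, on what has been measured and on what is new or still open speak of the compounds shown alone.

Compound 2 `CCOc1ccccc1-n1nncc1CN1C(=O)C2(C(C#N)=C(N)Oc3c2c2nc4ccccc4nc2c2ccccc32)c2ccccc21` gives only a limit in a functional assay on MCF7 cells (Homo sapiens) for antiproliferative activity, read by MTT assay, with a stated time of 48 h (a higher number here means a weaker inhibitor, a lower number a stronger inhibitor), > 50000 nM, so its position can be set no closer than that. Compound 1 `N#CC1=C(N)Oc2c(c3nc4ccccc4nc3c3ccccc23)C12C(=O)N(Cc1cnnn1-c1cccc(Cl)c1)c1ccccc12` gives 43600 nM in this assay. Among the compounds with values here, the single measured step, an at least 1.1-fold higher number from compound 1 to compound 2 (0.05 log units; that floor lies within the scatter), lies within the scatter, and the limit of > 50000 nM in this assay, at which 1 of the 2 values shown sits, caps what that step can show. Compound 3 `Cc1ccc(-n2nncc2CN2C(=O)C3(C(C#N)=C(N)Oc4c3c3nc5ccccc5nc3c3ccccc43)c3ccccc32)cc1Cl` carries 3-chloro-4-methylphenyl in place of 2-ethoxyphenyl on an aromatic nitrogen. Since the earlier aryl swap gave an at least 1.1-fold higher number from compound 1 to compound 2 (0.05 log units; that floor lies within the scatter) without leaving the scatter, no shift beyond the scatter is expected here either, an at least 1.1-fold lower number from compound 2 to compound 3 (0.04 log units; that floor lies within the scatter). Compound 3 is estimated at 45000 nM, within 20000 nM to 110000 nM, with a real chance of a limit only.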

Compound 3, half-maximal inhibitory concentration: > 50000 nM
Compound 3: a limit, no number; the forecaster's own chance of this, stated with the estimate: 50%; middle value at least 1.1-fold (0.04 log units) away from the limit.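

Compound 3 gives > 50000 nM in this assay, a limit and not a number. Methyl in place of hydrogen on an aromatic carbon, giving the 3-chloro-4-methylphenyl group, produces an at least 1.1-fold higher number from compound 1 to compound 3 (0.05 log units; that floor lies within the scatter), so this addition shows no readable shift, while the step between the two limits cannot be read. With three aryl groups now on the triazole nitrogen, readings at this position remain capped: the limit of > 50000 nM in this assay, at which 2 of the 3 values shown sit.

As far as these compounds go, whether an amine or a carboxylic acid on this aryl ring would bring a value clear of that limit stays open. So does the effect of a longer chain in place of the ethoxy group.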